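Ring size on the urea nitrogen: compound 3 to compound 4

The compounds below may be only part of what the source reports. "The series", "measured", "known", "first", "only" and "open" are said of these compounds alone.

In a functional assay on the whole organism for inhibition, with Mus musculus as the target, at a dose of 30 mg/kg by the oral route (on this read-out lower numbers stand for less inhibition and higher numbers for more inhibition at the one dose given (going by the name of the read-out)), compound 1 `CN(C(=O)NCCCOc1ccc2nc(O)ccc2c1)C1CCCCC1` gives 21%, compound 2 `O=C(NCCCOc1ccc2nc(O)ccc2c1)N(C1CCCCC1)C1CC1` gives 100%, and compound 3 `O=C(NCCCOc1ccc2nc(O)ccc2c1)N(C1CCCC1)[C@H]1CCCC[C@@H]1O` gives 78%. Compound 3 thus stands second highest of the three measured numbers, above compound 1 and below compound 2, both gaps beyond the scatter. Within the data shown here, the only measured single step, a number 79 percentage points higher from compound 1 to compound 2 (beyond the scatter), concerns a different substituent and does not bear directly on the change now in hand. Compound 4 `O=C(NCCCOc1ccc2nc(O)ccc2c1)N(C1CCCCC1)[C@H]1CCCC[C@@H]1O` differs from compound 3 by cyclohexyl in place of cyclopentyl on an amide-type nitrogen. Among the measured compounds shown here, compound 2 and compound 3 differ in two places, so their two values show only that a cyclohexyl-bearing compound reaches the top of the range. For the measured compounds named here, with no step that concerns this change, the step of a number 4 percentage points higher from compound 3 to compound 4 (within the scatter) is expected to lie within the scatter. Compound 4 is therefore estimated to give 82%, between 60% and 100%.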

Compound 4, a percentage reported as inhibition, in the whole organism at one dose (the size of the read-out at that dose, not a potency): 57%
Compound 4: the middle estimate sits 25 percentage points above what was measured; measured number outside the range, below it.
By their numbers in this assay, from the lowest: compound 1; then compound 4; then compound 3; then compound 2.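

In this assay, ring size on the amide-type nitrogen counts when the other substituent is 2-hydroxycyclohexyl: cyclohexyl in place of cyclopentyl costs inhibition (a number 21 percentage points lower from compound 3 to compound 4 (beyond the scatter)). With cyclohexyl held on that nitrogen, 2-hydroxycyclohexyl falls short of cyclopropyl (a number 43 percentage points lower from compound 2 to compound 4 (beyond the scatter)) but still exceeds methyl (a number 36 percentage points higher from compound 1 to compound 4 (beyond the scatter)). No measurement available here accounts for these steps.

On these data alone, whether cyclopentyl also outdoes cyclohexyl with cyclopropyl as the other substituent remains open. So does the effect of an amine or a carboxylic acid in place of the hydroxyl on the cyclohexyl ring.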